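The source may report more compounds than this note shows. Statements on the series, on what has been measured and on what is new or still open speak of the compounds shown alone.

Measured so far in a functional assay on the whole organism for agonist activity, with Mus musculus as the target; a lower number here means that less compound is needed, a higher number that more compound is needed for the effect:
Compound 1 `CC(=O)N(C)CC#CCn1ccnc1`: 1.4 mg/kg
Compound 2 `COC(=O)N(C)CC#CCn1ccnc1`: 4.5 mg/kg
Compound 3 `CN(C)C(=O)N(C)CC#CCN1CCCC1`: > 10 mg/kg

For compound 3 the reading > 10 mg/kg is a limit of this assay and not a number. Compound 4 `CN(C)C(=O)N(C)CC#CCn1ccnc1` differs from compound 3 in one group: 1H-imidazol-1-yl in place of pyrrolidin-1-yl on a saturated chain carbon bound to a triple-bonded carbon. In words, this is 1H-imidazol-1-yl in place of pyrrolidin-1-yl on a saturated chain carbon bound to a triple-bonded carbon.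

Among the measured compounds shown here, no measured step makes this exchange. For the measured compounds named here, the one measured step, a 3.2-fold higher number from compound 1 to compound 2 (0.51 log units; beyond the scatter), lies at a carbonyl carbon, and both of its compounds already carry 1H-imidazol-1-yl. Going by the values given here, it shows only that a change at the carbonyl carbon can shift the dose modestly beyond the scatter.

Compound 1 and compound 2, the two compounds with 1H-imidazol-1-yl, both give numbers, whereas compound 3, the one with pyrrolidin-1-yl, gives only a limit. A lower number than that of compound 3 is therefore expected for compound 4, though the size of the drop cannot be fixed from a limit. The expected change is an at least 2.0-fold lower number from compound 3 to compound 4 (0.30 log units; that floor lies within the scatter). The group on the carbonyl carbon of compound 4 matches neither compound 1 nor compound 2. The range is kept wide. For compound 4 the estimate is 5 mg/kg, with an expected range from 1.5 mg/kg to 20 mg/kg.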

Compound 4, dose for half-maximal effect: 25.4 mg/kg
Estimate against measurement, compound 4: 5.1-fold (0.71 log units) below; the whole stated range lies below it.
By their numbers in this assay, from the lowest: compound 1; then compound 2; then compound 4.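

With 1H-imidazol-1-yl held fixed, the group on the carbonyl carbon proves to span a wide range in this assay: dimethylamino in place of methoxy gives a 5.6-fold higher number from compound 2 to compound 4 (0.75 log units; beyond the scatter), and dimethylamino in place of methyl gives an 18-fold higher number from compound 1 to compound 4 (1.26 log units; beyond the scatter). Together with a 3.2-fold higher number from compound 1 to compound 2 (0.51 log units; beyond the scatter), these steps order compound 1, compound 2 and compound 4 by that one group, from methyl through methoxy to dimethylamino, with each step beyond the scatter. The exchange of pyrrolidin-1-yl for 1H-imidazol-1-yl itself cannot be read, because compound 3 stands at a limit and not at a number: the limit of > 10 mg/kg in this assay, at which 1 of the 4 values shown sits.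

On these data alone, it therefore remains open whether that exchange changes the dose at all when dimethylamino sits on the carbonyl carbon, and whether pyrrolidin-1-yl would give a readable number with methyl or methoxy on the carbonyl carbon instead. Also open, as far as these compounds go, is where an ethyl group or a cyclopropyl group on the carbonyl carbon would fall in this order, as the three groups compared here cannot show whether the trend extends to other groups.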